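Bromo to Chloro on a Shared Benzothiazole-Ether Core

The source may hold more compounds than are shown below. What is called first, only, known or untested is meant among the compounds shown, and "the series" means these compounds.

Of the compounds shown here, two have been measured in a functional assay on A549 cells (Homo sapiens) for cytotoxicity, read by MTT assay, with a stated time of 24 h; on this read-out lower numbers stand for stronger inhibition and higher numbers for weaker inhibition. Compound 1, `FC(F)(F)C(F)(F)C(F)(F)C(F)(F)C(F)(F)C(F)(F)CCn1cc(COc2ccccc2-c2nc3ccccc3s2)nn1`, gives 15100 nM. Compound 2, `Brc1ccc(-c2cc(COc3ccccc3-c3nc4ccccc4s3)on2)cc1`, gives 19200 nM in this assay, a number that sits within the usual scatter of compound 1. Compound 3, `Clc1ccc(-c2cc(COc3ccccc3-c3nc4ccccc4s3)on2)cc1`, carries chloro in place of bromo on an aromatic carbon, chloro in place of bromo on an aromatic carbon. For the measured compounds named here, no pair of measured compounds shows this change, so nothing beyond the scatter is expected from it. The step from compound 2 to compound 3 is estimated as a 1.0-fold lower number from compound 2 to compound 3 (0.00 log units; within the scatter). Compound 3 is therefore expected at 19000 nM, with a range from 9000 nM to 40000 nM.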

Compound 3, half-maximal inhibitory concentration: 18800 nM
Compound 3: the middle estimate sits 1.0-fold (0.00 log units) above what was measured; low and high end bracket the measured number.
By their numbers in this assay, from the lowest: compounds 1, 3 and 2 (each within the scatter of the next).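

For the compounds shown here, replacing 4-bromophenyl with 4-chlorophenyl gives the first direct reading at this position: in this assay, the change is (a 1.0-fold lower number from compound 2 to compound 3 (0.01 log units; within the scatter)). At this place on the ring, therefore, bromo and chloro cannot be told apart on this read-out. Nothing available here explains that result. The compounds shown leave open whether a fluoro group, an amine or a carboxylic acid at the same place would shift the number beyond the scatter. They also leave open what a plain hydrogen there would give.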